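From compound 2 to compound 3 in liver microsomes

The compounds below may be only part of what the source reports. "The series", "measured", "known", "first", "only" and "open" are said of these compounds alone.

Compound 1 `NCCCCN(C[C@@H]1Cc2ncccc2CN1)[C@H]1CCCc2cccnc21`: 98%
Compound 2 `NC(=O)NC/C=C\CN(C[C@H]1Cc2ncccc2CN1)[C@H]1CCCc2cccnc21`: 100%

Both values come from an ADME assay on microsomes from liver (Homo sapiens) for metabolic stability, using NADPH, with a stated time of 10 min; on this read-out lower numbers stand for a less stable compound and higher numbers for a more stable compound. Compound 2, at 100%, lies within the usual scatter of compound 1, at 98%, so the two cannot be told apart.

Compound 3 `CN(CCCCN(C[C@H]1Cc2ncccc2CN1)[C@H]1CCCc2cccnc21)C1CCOCC1` has not yet been measured. It departs from compound 2 by this change: a group of 11 heavy atoms (9 carbon, 1 nitrogen, 1 oxygen; one six-membered non-aromatic ring with 1 hetero atom) in place of a group of 7 heavy atoms (4 carbon, 2 nitrogen, 1 oxygen; no ring), on a saturated chain carbon bound to an amine nitrogen. The two measured compounds do not differ in one place only, so the data give no direct size for a comparable change. The reading of compound 2 at 100% leaves room for movement in one direction only, and a moderate fall is expected. The expected change is a number 15 percentage points lower from compound 2 to compound 3 (beyond the scatter). For compound 3 the estimated value is 85%, with an expected range from 60% to 100%.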

Compound 3, percent of the compound remaining: 100%
The estimate for compound 3 lay 15 percentage points below the measured number, and the stated range covers the measured number.
By their numbers in this assay, from the lowest: compounds 1, 2 and 3 (each within the scatter of the next).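

Read in this assay, replacing the group of 7 heavy atoms with no ring by the group of 11 heavy atoms with one six-membered non-aromatic ring gives no change at the digits printed from compound 2 to compound 3 (within the scatter) in this single-place comparison. Among the compounds shown here, the earlier pair differed in more than one place, so this is the first direct reading for a change on a saturated chain carbon bound to an amine nitrogen. At this place, the larger group with a ring and 0 hydrogen-bond donors leaves the read-out where it stood, and no measured evidence bearing on why accompanies the result.

The compounds shown leave open how a carboxylic acid or a longer chain at this place would read. They also leave open whether any group here would move the number beyond the scatter.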